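Sulfamoyl to Methanesulfonamido on the Diaryl Chain

The source may report more compounds than this note shows. Statements on the series, on what has been measured and on what is new or still open speak of the compounds shown alone.

Compound 1 `C[C@H](C#Cc1cccc(C(=O)NCCC(c2ccccc2)c2ccc(Cl)c(Cl)c2)c1)N(O)C(N)=O` gives 96 nM in an assay for inhibition of Polyunsaturated fatty acid 5-lipoxygenase (Homo sapiens), read by HPLC, with stated times of 15 min and 10 min; a lower number here means a stronger inhibitor, a higher number a weaker inhibitor. Compound 2 `C[C@H](C#Cc1cccc(C(=O)NCCC(c2ccccc2)c2ccc(S(N)(=O)=O)cc2)c1)N(O)C(N)=O` gives 1000 nM in this assay, the highest of the two numbers shown; the step of a 10-fold higher number from compound 1 to compound 2 (1.02 log units; beyond the scatter) separates them. Compound 3 `C[C@H](C#Cc1cccc(C(=O)NCCC(c2ccccc2)c2ccc(NS(C)(=O)=O)cc2)c1)N(O)C(N)=O` differs from compound 2 by methanesulfonamido in place of sulfamoyl on an aromatic carbon. Among the measured compounds shown here, no measured step covers this kind of change: the only step available, a 10-fold higher number from compound 1 to compound 2 (1.02 log units; beyond the scatter), exchanges the whole aryl group and says nothing about swapping one sulfur-bearing substituent for another on the same ring. The expectation therefore rests on the value of compound 2 alone, since nothing in the data points to either direction. On that basis the step of a 1.3-fold lower number from compound 2 to compound 3 (0.10 log units; within the scatter) is expected to remain within the scatter. Compound 3 is accordingly estimated at 800 nM in this assay, with a range from 200 nM to 3000 nM.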

Compound 3, half-maximal inhibitory concentration: 900 nM
Estimate against measurement, compound 3: 1.1-fold (0.05 log units) below, within the range that was stated.
By their numbers in this assay, from the lowest: compound 1; then compounds 3 and 2 (each within the scatter of the next).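

In this assay, putting methanesulfonamido in place of sulfamoyl on this aromatic carbon gives a 1.1-fold lower number from compound 2 to compound 3 (0.05 log units; within the scatter), so compound 2 and compound 3 cannot be told apart, even though the sulfur-bearing group is joined to the ring through a different atom. The large gap seen earlier also persists with this second sulfur-bearing group, with a 9.4-fold higher number from compound 1 to compound 3 (0.97 log units; beyond the scatter), so compound 1, with its 3,4-dichlorophenyl, stands apart from both sulfur-bearing compounds. No available evidence accounts for either the match or the gap.

These compounds leave open whether the gap goes with the sulfur-bearing groups themselves or with the loss of the two chlorines. A single chlorine, an amine or a carboxylic acid on the same aromatic carbon would help to separate those two readings.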